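The source may hold more compounds than are shown below. What is called first, only, known or untested is meant among the compounds shown, and "the series" means these compounds.

Compound 1 `COc1ccc(-c2[nH]c(SC(F)(F)F)nc2-c2ccc(F)cc2)cc1`: 2.7 mg/kg
Compound 2 `O=S(=O)(c1nc(-c2ccc(Cl)c(Cl)c2)c(-c2ccccc2)[nH]1)C(F)(F)F`: 0.35 mg/kg

In a functional assay on the whole organism with Rattus norvegicus as the target (a higher number here means that more compound is needed for the effect, a lower number that less compound is needed), compound 1 stands at 2.7 mg/kg, the higher of the two numbers, while compound 2 gives 0.35 mg/kg, a gap beyond the usual scatter. These two compounds differ in more than one place, so no single change has yet been measured on its own.

Compound 3 `COc1ccc(-c2[nH]c(S(=O)(=O)C(F)(F)F)nc2-c2ccc(F)cc2)cc1` departs from compound 1 in one place, with (trifluoromethyl)sulfonyl in place of (trifluoromethyl)sulfanyl on an aromatic carbon. Compound 2 also carries (trifluoromethyl)sulfonyl and gives 0.35 mg/kg, although its other groups differ, so a lower number is expected in this assay, with a step probably beyond the scatter. The expected size is a 3.4-fold lower number from compound 1 to compound 3 (0.53 log units; beyond the scatter). For compound 3 the estimated value is 0.8 mg/kg, with an expected range of 0.25 mg/kg to 2.5 mg/kg.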

Compound 3, dose for half-maximal effect: 1.4 mg/kg
Beside the measured number, compound 3's estimate is 1.8-fold (0.24 log units) below it; measured number inside the range.
By their numbers in this assay, from the lowest: compound 2; then compounds 3 and 1 (each within the scatter of the next).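

Moving from (trifluoromethyl)sulfanyl to (trifluoromethyl)sulfonyl on the aromatic carbon between two ring nitrogen atoms gives, in this assay, a 1.9-fold lower number from compound 1 to compound 3 (0.29 log units; within the scatter). For the compounds shown here, this is the first single change measured on its own, and on the core of compound 1 the two groups cannot be told apart in this whole-animal read-out, so this position accepts either one with its effect intact. Nothing available bears on what lies behind this result.

On these data alone, it remains open whether the same exchange would also stay within the scatter with other groups on the two aromatic rings, such as a chlorine in place of the fluorine of the 4-fluorophenyl group. As far as these compounds go, it is also open how this position would respond to a group of another kind, such as a nitrile, an amine or a plain methyl, in place of either sulfur-bearing group.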